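The source may report more compounds than this note shows. Statements on the series, on what has been measured and on what is new or still open speak of the compounds shown alone.

In a functional assay on PC-3 cells (Homo sapiens) for antiproliferative activity, read by MTT assay, with a stated time of 72 h (on this read-out higher numbers stand for weaker inhibition and lower numbers for stronger inhibition), compound 1 (`O=C(N/N=C/c1ccccc1)Nc1ccc(Oc2ccnc3[nH]ccc23)c(F)c1`) reads 7940 nM and compound 2 (`COc1ccc(/C=N/NC(=O)Nc2ccc(Oc3ccnc4[nH]ccc34)c(F)c2)cc1`) reads 6730 nM on the shared core, and the methoxy step between them (a 1.2-fold lower number from compound 1 to compound 2 (0.07 log units; within the scatter)) lies within the scatter. Compound 3 (`CN(C)CCn1cccc1/C=N/NC(=O)Nc1ccc(Oc2ccnc3[nH]ccc23)c(F)c1`) reads 1600 nM and holds the lowest number of the three, so it shows the strongest inhibition so far.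

Compound 4 (`O=C(N/N=C/c1cccn1CCCN1CCCC1)Nc1ccc(Oc2ccnc3[nH]ccc23)c(F)c1`) is not yet measured. Its difference from compound 3 is confined to the side chain on the aromatic nitrogen ((pyrrolidin-1-yl)methyl in place of dimethylamino on a saturated chain carbon, two bonds along the chain from an aromatic nitrogen). Cut one bond further out, the same difference reads 2-(dimethylamino)ethyl to 3-(pyrrolidin-1-yl)propyl.

Within the data shown here, no measured step alters this side chain alone. The nearest evidence is the pair of modest steps into compound 3 (a 5.0-fold lower number from compound 1 to compound 3 (0.70 log units; beyond the scatter)) and (a 4.2-fold lower number from compound 2 to compound 3 (0.62 log units; beyond the scatter)), and each of these exchanged the whole group on the carbon with a double bond to nitrogen. Compound 4 keeps the pyrrole unit gained in those steps, so those sizes serve only as an outer guide. In this assay no step beyond the scatter is expected, and no direction is favoured, though a modest move either way remains possible. The estimated step is small (a 1.1-fold lower number from compound 3 to compound 4 (0.03 log units; within the scatter)) on this basis. For compound 4 the expected value is 1500 nM with an estimated range from 600 nM to 3800 nM on this read-out.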

Compound 4, half-maximal inhibitory concentration: 3580 nM
The estimate for compound 4 lay 2.4-fold (0.38 log units) below the measured number; the measured number falls inside the stated range.
By their numbers in this assay, from the lowest: compound 3; then compounds 4, 2 and 1 (each within the scatter of the next, the first and the last beyond it).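

Among these compounds, compound 4 gives the first direct reading of the side chain on the aromatic nitrogen: in this assay, exchanging this side chain alone gives a 2.2-fold higher number from compound 3 to compound 4 (0.35 log units; beyond the scatter), so this position does respond to change and, in this single step, the larger group reads weaker. Cut one bond further out, the difference reads 2-(dimethylamino)ethyl to 3-(pyrrolidin-1-yl)propyl, which means that a longer chain and a five-membered non-aromatic ring enter together, and this one step cannot divide its size between them. No measurement is available that bears on the origin of this step.

The compounds shown leave open whether chain length or the ring carries the step, and a 3-(dimethylamino)propyl chain and a 2-(pyrrolidin-1-yl)ethyl chain on the same aromatic nitrogen would each hold one of the two changes alone. Also open, on these data alone, is how this position reads with a chain ending in a morpholine ring, a hydroxyl group or a carboxylic acid instead of the amines seen in compound 3 and compound 4.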